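The source may hold more compounds than are shown below. What is called first, only, known or untested is meant among the compounds shown, and "the series" means these compounds.

Measured in a functional assay on HepG2 cells (Homo sapiens) for cytotoxicity, read by MTT assay, with a stated time of 72 h; on this read-out higher numbers stand for lower toxicity in this test and lower numbers for higher toxicity in this test:
compound 1 `CS/C(=N\C(=O)c1cc2ccccc2s1)NC(=O)c1cc2ccccc2s1`: 75800 nM
compound 2 `CS/C(=N\C(=O)c1ccco1)NC(=O)c1ccco1`: > 100000 nM, which is a limit of the assay and not a number
compound 3 `O=C(/N=C(/NC(=O)c1ccco1)[Se]Cc1ccccc1)c1ccco1`: 76500 nM

Of the compounds shown here, three have been measured in this assay. How the core of compound 1 differs from the core of compound 2 is not broken down here. For compound 2 only a limit is known, (the limit of > 100000 nM in this assay, at which 1 of the 3 values shown sits). From compound 2 to compound 3 the change is a group of 8 heavy atoms (7 carbon, 1 selenium; one six-membered aromatic ring of carbon only) in place of a group of 2 heavy atoms (1 carbon, 1 sulfur; no ring), on a carbon with a double bond to nitrogen, and that change made an at least 1.3-fold lower number from compound 2 to compound 3 (0.11 log units; that floor lies within the scatter). Compound 1 and compound 3 sit within the scatter of each other.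

Compound 4 `O=C(/N=C(/NC(=O)c1cc2ccccc2s1)[Se]Cc1ccccc1)c1cc2ccccc2s1` has not yet been measured. Relative to compound 1 it carries the same change: a group of 8 heavy atoms (7 carbon, 1 selenium; one six-membered aromatic ring of carbon only) in place of a group of 2 heavy atoms (1 carbon, 1 sulfur; no ring), on a carbon with a double bond to nitrogen. Among the measured compounds shown here, the one measured example of this change, from compound 2 to compound 3, gives only a floor that lies within the scatter, so little movement is expected here either. Compound 4 is estimated at 58000 nM in this assay, with an expected range from 28000 nM to 100000 nM. This estimate means an expected step of a 1.3-fold lower number from compound 1 to compound 4 (0.12 log units; within the scatter), resting on an at least 1.3-fold lower number from compound 2 to compound 3 (0.11 log units; that floor lies within the scatter).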

Compound 4, concentration lethal to 50% of the cells: 77000 nM
Beside the measured number, compound 4's estimate is 1.3-fold (0.12 log units) below it; low and high end bracket the measured number.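

In this assay, putting the selenium-bearing group with its six-membered aromatic ring in place of methylsulfanyl, on the carbon with a double bond to nitrogen, gave a 1.0-fold higher number from compound 1 to compound 4 (0.01 log units; within the scatter), so on the core of compound 1 this change stays within the scatter. Set beside the earlier example, the two cores read as follows: the same change on two cores in this assay, an at least 1.3-fold lower number (0.11 log units; that floor lies within the scatter) from compound 2 to compound 3 and a 1.0-fold higher number (0.01 log units; within the scatter) from compound 1 to compound 4; the limit leaves it open whether they differ. From the compounds shown here alone, this shows no step beyond the scatter on either core, but it does not show that the change carries over unaltered, since the step on the other core has only a floor and its full size is unknown, and that floor comes from a limit of the assay and not a number: the limit of > 100000 nM in this assay, at which 1 of the 4 values shown sits.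

The compounds shown leave open how a third core would respond to the same change. They also leave open how the number would read with benzylsulfanyl, an amine or a longer chain on that same carbon.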